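The source may hold more compounds than are shown below. What is called first, only, known or untested is meant among the compounds shown, and "the series" means these compounds.

Measured in an ADME assay on microsomes from liver (Homo sapiens) for metabolic stability, read by LC-MS, using NADPH, with a stated time of 120 min, tested at 1 uM; on this read-out lower numbers stand for a shorter-lived compound and higher numbers for a longer-lived compound:
- compound 1 `COc1cccc(OC)c1-c1cc(C(=O)N[C@@H](CCC2CCCCC2)CC(=O)NC2CCC2)nn1C1CCCC1`: 0.104 h
- compound 2 `COc1cccc(OC)c1-c1cc(C(=O)N[C@@H](CCN2CCCCC2)CC(=O)NC2CC(F)(F)C2)nn1C1CCCC1`: 0.633 h

Compound 2 is the longer-lived of the two, and the gap lies beyond the usual scatter. Compound 3 `COc1cccc(OC)c1-c1cc(C(=O)N[C@@H](CCN2CCCCC2)CC(=O)Nc2nnn[nH]2)nn1C1CCCC1` differs from compound 2 at one place, on an amide-type nitrogen: 1H-tetrazol-5-yl in place of 3,3-difluorocyclobutyl on an amide-type nitrogen. Among the measured compounds shown here, no measured pair differs in one place only, so the data do not show what such a swap does in this assay, and any forecast is loose. Starting from compound 2 at 0.633 h, a modest rise near the edge of the scatter is expected, with a 1.9-fold higher number from compound 2 to compound 3 (0.28 log units; within the scatter) as the estimated step. Compound 3 is estimated at 1.2 h, with a range of 0.35 h to 4 h.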

Compound 3, half-life: 0.403 h
The estimate for compound 3 lay 3.0-fold (0.47 log units) above the measured number; the measured number falls inside the stated range.
By their numbers in this assay, from the lowest: compound 1; then compounds 3 and 2 (each within the scatter of the next).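

In this assay, putting 1H-tetrazol-5-yl in place of 3,3-difluorocyclobutyl on an amide-type nitrogen gives a 1.6-fold lower number from compound 2 to compound 3 (0.20 log units; within the scatter). This position therefore takes a five-membered aromatic ring with 4 hetero atoms instead of a four-membered ring of carbon only, and the half-life stays within the usual scatter. Nothing measured here explains this result.

Compound 1 differs from the others in more than one place, so it cannot show what this position does alone. Going by these compounds, how a methyl or phenyl group on this nitrogen would behave remains open.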